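Ring nitrogen demethylation in a fused urea series

This account rests on a few compounds, and the source may have more. Where it says the series, first, only, none or still open, it means among the compounds named here.

Two members of the series have been measured in an assay on isolated protein for inhibition of proto-oncogene tyrosine-protein kinase receptor Ret variant V804L (Homo sapiens), read by 33P incorporation, with stated times of 15 min and 40 min; on this read-out lower numbers stand for stronger inhibition and higher numbers for weaker inhibition. Compound 1 `O=C(Nc1ccc(Nc2ncnc3c2OCCN3)cc1)Nc1cccc(-c2ccccc2)c1` reports only a limit of the assay, > 10000 nM, and no number. For the measured compounds named here, compound 2 `CN1CCCOc2c(Nc3ccc(NC(=O)Nc4cc(C(C)(C)C)on4)cc3)ncnc21` gives 1130 nM in this assay, the only real number so far. The other reading shown is the limit (the limit of > 10000 nM in this assay, at which 1 of the 2 values shown sits). Compound 1 and compound 2 differ in more than one place, so their two values show no more than that one returns a number and the other does not.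

Compound 3 `CC(C)(C)c1cc(NC(=O)Nc2ccc(Nc3ncnc4c3OCCCN4)cc2)no1` is not yet measured. It differs from compound 2 by hydrogen in place of methyl on a nitrogen on an aromatic ring in a ring. Going by the values given here, no pair differing at a single place has been measured, so the size of such a step is unknown from the data. Given that compound 2 gives 1130 nM and the change removes only one methyl, the expected step of a 1.3-fold higher number from compound 2 to compound 3 (0.12 log units; within the scatter) is small, within or just beyond the scatter, with no fixed direction. Compound 3 is therefore estimated at 1500 nM in this assay, with a range from 500 nM to 5000 nM.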

Compound 3, half-maximal inhibitory concentration: 9 nM
Compound 3: middle estimate off by 170-fold (2.22 log units), on the high side; measured number below the stated range.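

In this assay, for the compounds shown here, the nitrogen of the seven-membered non-aromatic ring proves to be a highly sensitive place: hydrogen in place of methyl gives a 130-fold lower number from compound 2 to compound 3 (2.10 log units; beyond the scatter), the only single-place step available and one well beyond the scatter. Only one heavy atom leaves, a methyl with 1 carbon, and no ring changes, so the smallest possible edit at this nitrogen is enough to move the reading by a large margin. Going by these compounds alone, nothing measured so far gives a reason for a step of this size.

From the compounds shown here alone, this conclusion rests on a single pair, so it remains open whether the step keeps its size in compounds carrying another urea substituent, or is particular to the pair of compound 2 and compound 3. Also open, going by these compounds, is what an ethyl, a longer chain or an acetyl on this nitrogen would give in this assay, and so whether every group other than hydrogen brings a weaker reading there or methyl alone does.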